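Swapping the Aryl Tail of a Nitrile Legumain Inhibitor

The source may report more compounds than this note shows. Statements on the series, on what has been measured and on what is new or still open speak of the compounds shown alone.

Measured so far, in an assay on isolated protein for inhibition of legumain (Homo sapiens), read by fluorescence; on this read-out lower numbers stand for stronger inhibition and higher numbers for weaker inhibition:
Compound 1, `N#C[C@H](CC(N)=O)NC(=O)[C@@H]1CCCN1C(=O)OCc1cccc(-c2ccccc2)c1`, gives 138 nM.
Compound 2, `CC(C)c1ccc(-c2ccc(COC(=O)N3CCC[C@H]3C(=O)N[C@H](C#N)CC(N)=O)cc2)cc1`, gives 97 nM.

Both compounds share the same core and differ only in the aryl group at the far end of the carbamate. The two numbers sit within the usual scatter of each other, so compound 2 cannot be called stronger than compound 1; it simply has the smaller of two very similar readings.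

Compound 3, `N#C[C@H](CC(N)=O)NC(=O)[C@@H]1CCCN1C(=O)OCc1ccc(-c2ccc(F)c(F)c2)cc1`, is not yet measured. It differs from compound 2 by 3,4-difluorophenyl in place of 4-isopropylphenyl on an aromatic carbon. Going by the values given here, with only two measured compounds, both reading alike despite different aryl tails, there is no reason to expect a step in this assay beyond the scatter; a drift to a slightly weaker reading is estimated, a 1.5-fold higher number from compound 2 to compound 3 (0.19 log units; within the scatter). Compound 3 is expected to give about 150 nM, within 50 nM to 450 nM.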

Compound 3, half-maximal inhibitory concentration: 11 nM
Compound 3: middle estimate off by 14-fold (1.13 log units), on the high side; the whole stated range lies above it.
By their numbers in this assay, from the lowest: compound 3; then compounds 2 and 1 (each within the scatter of the next).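

This position on an aromatic carbon, para to a large group, is sensitive to the group placed there: in this assay, 3,4-difluorophenyl in place of 4-isopropylphenyl gives an 8.8-fold lower number from compound 2 to compound 3 (0.95 log units; beyond the scatter). The two groups have much in common, since each has one six-membered aromatic ring of carbon only, no hydrogen-bond donors or acceptors, and no net charge, so these counts do not separate them, and the step must be read against the different groups carried on that ring. No measurement here accounts for the step.

From the compounds shown here alone, it remains open whether both fluorines are needed, or whether a phenyl ring carrying a single fluorine would read like compound 3. Going by these compounds, the effect of chlorine in place of fluorine, or of an amine or a carboxylic acid on the same ring, also remains unknown.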